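The source may hold more compounds than are shown below. What is called first, only, known or untested is meant among the compounds shown, and "the series" means these compounds.

Compound 2 `Nc1scc(CN2CCN(c3ccccc3C(F)(F)F)CC2)c1C(=O)c1ccc(Cl)cc1` gives 0% in an assay on CHO cells for displacement of a labelled ligand from adenosine receptor A1 (Homo sapiens), read by scintillation counting, with a stated time of 120 min, tested at 10 uM; on this read-out lower numbers stand for less inhibition and higher numbers for more inhibition at the one concentration tested (going by the name of the read-out). Within the measured set it stands level with compound 1 `COc1ccc(N2CCN(Cc3csc(N)c3C(=O)c3ccc(Cl)cc3)CC2)cc1`, which gives 0% in this assay, and with compound 3 `Nc1scc(CN2CCN(c3ccc(F)c(F)c3)CC2)c1C(=O)c1ccc(Cl)cc1`, which gives 0% in this assay. The three steps among these compounds, no change at the digits printed from compound 1 to compound 2 (within the scatter), no change at the digits printed from compound 1 to compound 3 (within the scatter) and no change at the digits printed from compound 2 to compound 3 (within the scatter), each exchange one aryl group for another on the amine nitrogen in the ring, and every one of them lies within the scatter.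

Compound 4 `Nc1scc(CN2CCN(CCCc3ccc(Cl)cc3)CC2)c1C(=O)c1ccc(Cl)cc1` is not yet measured. It differs from compound 2 as follows: 3-(4-chlorophenyl)propyl in place of 2-(trifluoromethyl)phenyl on an amine nitrogen in a ring. Among the compounds with values here, no measured step replaces the aryl group on that nitrogen with a chain such as the 3-(4-chlorophenyl)propyl group, so the bearing of the three steps is indirect: they show only that the group on this nitrogen, among the variations tried, did not move the read-out in this assay. On that basis no step beyond the scatter is expected, a number 2 percentage points higher from compound 2 to compound 4 (within the scatter). Compound 4 is therefore estimated at 2% in this assay, with a range from -8% to 18%.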

Compound 4, a percentage reported as inhibition, at one concentration (the size of the read-out at that concentration, not a potency): 0%
Beside the measured number, compound 4's estimate is 2 percentage points above it, and the stated range covers the measured number.
By their numbers in this assay, from the lowest: compounds 1, 2, 3 and 4 (each within the scatter of the next).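

In this assay, the move from an aryl group on the amine nitrogen in the ring to the chain-linked 3-(4-chlorophenyl)propyl gives no change at the digits printed from compound 2 to compound 4 (within the scatter) and no change at the digits printed from compound 3 to compound 4 (within the scatter) and no change at the digits printed from compound 1 to compound 4 (within the scatter) for the three comparisons. The result extends the flat reading at this position from aryl groups to an aryl group carried on a propyl chain, although a set this flat cannot separate the groups from one another. No available evidence bears on the reason for this flat reading.

Still open, from the compounds shown here alone, is whether a carboxylic acid or a second amine at the end of a longer chain on this nitrogen would give a different reading. Also open, going by these compounds, is whether replacing the 4-chlorophenyl carbonyl group of the shared core with an amide would change the reading in this assay for these compounds.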